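The compounds below may be only part of what the source reports. "The series", "measured", "known", "first", "only" and "open" are said of these compounds alone.

Measured compounds:
compound 1 `O=C([C@H]1O[C@@H](n2cnc3c(NCc4cccc(I)c4)nc(Cl)nc32)[C@H](O)[C@@H]1O)N1CCOCC1` — 513 nM
compound 2 `O=C(NCc1cccc(Cl)c1)[C@H]1O[C@@H](n2cnc3c(NCc4cccc(I)c4)nc(Cl)nc32)[C@H](O)[C@@H]1O` — 309 nM

For the measured compounds named here, in an assay on CHO cells for displacement of a labelled ligand from adenosine receptor A3 (Homo sapiens) (a lower number here means a stronger inhibitor, a higher number a weaker inhibitor), compound 1 gives 513 nM, the higher of the two numbers so far; its nearest neighbour is compound 2, which gives 309 nM. Going by the values given here, the single measured step, a 1.7-fold lower number from compound 1 to compound 2 (0.22 log units; within the scatter), exchanges the group on the carbonyl carbon and stays within the scatter, so the two measured values are best read as equivalent.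

Compound 3 `Cc1ccccc1CNc1nc(Cl)nc2c1ncn2[C@@H]1O[C@H](C(=O)N2CCOCC2)[C@@H](O)[C@H]1O` is not yet measured. It differs from compound 1 at a different position: 2-methylphenyl in place of 3-iodophenyl on a saturated chain carbon bound to a nitrogen on an aromatic ring. Among the compounds with values here, no measured pair touches the saturated chain carbon bound to a nitrogen on an aromatic ring, so the step from compound 1 to compound 2 does not bear on this change, and the series gives no anchor for its size or direction. On these data alone, with the 3-iodophenyl group present in both measured compounds, the effect of its removal is untested and the range must stay wide. Compound 3 is expected to give a higher number, a 2.3-fold higher number from compound 1 to compound 3 (0.37 log units; beyond the scatter), with the estimate for compound 3 set at 1200 nM and bounded by 300 nM and 5000 nM.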

Compound 3, inhibition constant: 7590 nM
Beside the measured number, compound 3's estimate is 6.3-fold (0.80 log units) below it, outside the stated range (above it).
By their numbers in this assay, from the lowest: compounds 2 and 1 (each within the scatter of the next); then compound 3.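

In this assay, for the compounds shown here, the saturated chain carbon bound to a nitrogen on an aromatic ring is a position that responds strongly to substitution: 2-methylphenyl in place of 3-iodophenyl gives a 15-fold higher number from compound 1 to compound 3 (1.17 log units; beyond the scatter), whereas the only earlier step, made on a carbonyl carbon, stayed within the scatter. The large step appears although the heavy-atom count stays the same, a six-membered aromatic ring of carbon only remains, and both groups have no hydrogen-bond donors or acceptors, so these counts do not distinguish the two groups. No measurement available here accounts for the size of the step.

The compounds shown do not separate the removal of iodine from the introduction of the 2-methylphenyl group, and an unsubstituted phenyl group on the same carbon would provide a reference for reading those two parts. On these data alone, it also remains open whether the same exchange would give a step of similar size with (3-chlorobenzyl)amino on the carbonyl carbon, as in compound 2, instead of morpholin-4-yl.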